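The compounds below may be only part of what the source reports. "The series", "measured", "known", "first", "only" and "open" are said of these compounds alone.

Measured in a functional assay on MCF7 cells (Homo sapiens) for cytotoxicity, read by MTT assay, with a stated time of 24 h; a higher number here means a weaker inhibitor, a lower number a stronger inhibitor:
- compound 1 `COc1ccc(Cc2cn3cc(Br)ccc3nc2=O)cc1`: > 1000000 nM (a limit)
- compound 2 `O=c1nc2ccccn2cc1Cc1ccc(F)cc1C(F)(F)F`: 9870 nM
- compound 3 `Cc1ccc(Cc2cn3cc(Cl)ccc3nc2=O)cc1`: > 1000000 nM (a limit)

Compound 3 has no numerical value, only the limit > 1000000 nM. It stands at the limit of > 1000000 nM in this assay, at which 2 of the 3 values shown sit. Within the data shown here, compound 2 is the only compound here with a number.

Compound 4 `O=c1nc2ccc(Cl)cn2cc1Cc1ccc(F)cc1` changes compound 3 in one place: fluoro in place of methyl on an aromatic carbon. This puts fluoro in place of methyl on an aromatic carbon, para to a large group.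

Among the measured compounds shown here, with no step between measured compounds to draw on, the size of this change in this assay is uncertain. Some gain in potency is expected, though it may not be large enough to leave the limit. The expectation rests on compound 2, which also carries a fluoro on its carbon-only aromatic ring and gives 9870 nM. Compound 2 differs from compound 4 elsewhere as well, so the range is wide.

The expected change is an at least 10-fold lower number from compound 3 to compound 4 (1.00 log units; beyond the scatter).

The estimate for compound 4 is 100000 nM, with an expected range from 8000 nM to 1000000 nM.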

Compound 4, half-maximal inhibitory concentration: 10400 nM
Estimate against measurement, compound 4: 9.6-fold (0.98 log units) above, and the stated range covers the measured number.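

In this assay, fluoro in place of methyl on an aromatic carbon, para to a large group, gives an at least 96-fold lower number from compound 3 to compound 4 (1.98 log units; beyond the scatter). Among these compounds, this is the first single-place step, and it shows that one atom at this position of the carbon-only ring can separate a compound at the limit from one with a measurable value. Compound 3 has a limit and not a number, so the step gives only a bound on the size of the change: the limit of > 1000000 nM in this assay, at which 2 of the 4 values shown sit.

The compounds shown do not tell whether this shift is specific to fluoro or would also appear with a nitrile or an amine in the same place. They also leave open whether fluoro in that place gives a measurable value with the bromo of compound 1 on the shared core.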